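The source may report more compounds than this note shows. Statements on the series, on what has been measured and on what is new or still open speak of the compounds shown alone.

Measured so far in an assay on isolated protein for displacement of a labelled ligand from 5-hydroxytryptamine receptor 6 (Homo sapiens), read by scintillation counting, with a stated time of 1 h; on this read-out higher numbers stand for weaker inhibition and lower numbers for stronger inhibition: compound 1 `CN(C)c1cccc2c1ccn2S(=O)(=O)c1ccccc1` gives 65 nM; compound 2 `O=S(=O)(c1ccccc1)n1ccc2c(-c3ccccc3)cccc21` gives 162 nM.

Compound 1 has the lower of the two numbers; the step of a 2.5-fold higher number from compound 1 to compound 2 (0.40 log units; beyond the scatter) changes a substituent on the shared core, not the sulfonyl group.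

Compound 3 `CN(C)c1cccc2c1ccn2S(=O)(=O)N1CCCCC1` differs from compound 1 by piperidin-1-yl in place of phenyl on a sulfonyl sulfur. Going by the values given here, no measured step touches the group on the sulfonyl sulfur, so the step of a 2.5-fold higher number from compound 1 to compound 2 (0.40 log units; beyond the scatter) does not bear on this change and no direction can be read from the data.

Compound 3 is therefore expected near 150 nM, within 40 nM to 600 nM, an expected step of a 2.3-fold higher number from compound 1 to compound 3 (0.36 log units; beyond the scatter) from compound 1.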

Compound 3, inhibition constant: 39100 nM
Estimate against measurement, compound 3: 260-fold (2.42 log units) below; the whole stated range lies below it.
By their numbers in this assay, from the lowest: compound 1; then compound 2; then compound 3.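

In this assay the group on the sulfonyl sulfur carries far more weight than the substituent changed earlier: piperidin-1-yl in place of phenyl gives a 600-fold higher number from compound 1 to compound 3 (2.78 log units; beyond the scatter) against a 2.5-fold higher number from compound 1 to compound 2 (0.40 log units; beyond the scatter) for the change on an aromatic carbon. The two groups have the same heavy-atom count, so the large step comes with a change of ring type and the entry of one nitrogen, not of size by that count. Nothing available accounts for this step.

Which of these two differences matters stays open. A cyclohexyl or pyridine ring on the sulfonyl sulfur would separate them.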